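Dimethylcarbamoyl in place of carbamoyloxymethyl on the chain

The source may report more compounds than this note shows. Statements on the series, on what has been measured and on what is new or still open speak of the compounds shown alone.

Compound 1 `CC1=C(N2CC2)C(=O)C(CCCOC(N)=O)=C(N2CC2)C1=O` is measured in a functional assay on L1210 cells (Mus musculus), with a stated time of 1 days (a lower number here means a less potent compound, a higher number a more potent compound, by a factor of ten per unit of this negative logarithm), and gives 5.55. Compound 2 `CCOC(COC(N)=O)C1=C(N2CC2)C(=O)C(C)=C(N2CC2)C1=O` gives 5.53, within the scatter of compound 1. Compound 3 `CCCC1=C(N2CC2)C(=O)C(CCC)=C(N2CC2)C1=O` gives 4.32, beyond the scatter below compound 1, so compound 1 stands with compound 2 at the top of the three numbers. Compound 4 `CC1=C(N2CC2)C(=O)C(CCC(=O)N(C)C)=C(N2CC2)C1=O` is not yet measured. It differs from compound 1 as follows: dimethylcarbamoyl in place of (carbamoyloxy)methyl on a saturated chain carbon, two bonds along the chain from a double-bonded ring carbon. Going by the values given here, no measured pair shows this change alone. Compound 3, which also carries no carbamate, gives 4.32, and compound 4 is therefore expected to fall by a moderate step, a number 0.55 log units lower from compound 1 to compound 4 (beyond the scatter), though compound 3 differs from compound 1 in more than one place. Compound 4 is estimated at 5, between 4.3 and 5.6.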

Compound 4, logarithm of the reciprocal of the active concentration, log(1/C): 5.09
The estimate for compound 4 lay 0.09 log units below the measured number, and the stated range covers the measured number.
By their numbers in this assay, from the lowest: compound 3; then compound 4; then compounds 2 and 1 (each within the scatter of the next).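

Dimethylcarbamoyl in place of (carbamoyloxy)methyl on this saturated chain carbon gives a number 0.46 log units lower from compound 1 to compound 4 (beyond the scatter) in this assay on an otherwise unchanged core, the only single-place step in the series so far. The carbamate is therefore not required at this position for compound 4 to reach 5.09 in its read-out, though the change costs a modest step. No evidence at hand accounts for that step. From the compounds shown here alone, the change swaps the whole group at once, so the part of it that drives the step stays open. A primary amine or a carboxylic acid in place of dimethylcarbamoyl, or a longer chain carrying it, would help to separate these parts.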